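The source may report more compounds than this note shows. Statements on the series, on what has been measured and on what is new or still open speak of the compounds shown alone.

Working notes on the sulfonyl urea series. Compound 1 `O=C(NCc1ccc(S(=O)(=O)c2ccccc2)cc1)NCc1cccnc1` gives 610 nM in a functional assay on A2780 cells (Homo sapiens) for cytotoxicity, read by sulforhodamine B assay, with a stated time of 72 h; a higher number here means a weaker inhibitor, a lower number a stronger inhibitor. Compound 2 `O=C(NCc1ccc(S(=O)(=O)c2ccccc2)cc1)N1CCc2ccncc2C1` reaches only a limit of this assay, recorded as > 2000 nM. Compound 3 `O=C(NCc1ccc(S(=O)(=O)C2CCC(F)(F)CC2)cc1)N1Cc2ccncc2C1` gives 13 nM in this assay, the lowest of the two numbers shown; its gap to compound 1 lies well beyond the scatter. The remaining entry, that of compound 2, is a limit rather than a number. Compound 4 `O=C(NCc1ccc(S(=O)(=O)N2CCC[C@@H](O)C2)cc1)N1Cc2ccncc2C1` has not yet been measured and differs from compound 3 by 3-hydroxypiperidin-1-yl in place of 4,4-difluorocyclohexyl on a sulfonyl sulfur. For the measured compounds named here, no measured pair in the set isolates this change, so nothing here sets its size. A modest loss is expected, somewhat beyond the scatter, the expected step being a 3.1-fold higher number from compound 3 to compound 4 (0.49 log units; beyond the scatter). Compound 4 is estimated at 40 nM, within a range from 8 nM to 250 nM.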

Compound 4, half-maximal inhibitory concentration: 70 nM
Compound 4: middle estimate off by 1.8-fold (0.24 log units), on the low side; measured number inside the range.
By their numbers in this assay, from the lowest: compound 3; then compound 4; then compound 1. At a limit, above all of these: compound 2.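

At this position on a sulfonyl sulfur, 3-hydroxypiperidin-1-yl in place of 4,4-difluorocyclohexyl costs only a modest amount in this assay, with a 5.4-fold higher number from compound 3 to compound 4 (0.73 log units; beyond the scatter) on the shared core. Activity therefore survives a ring with a hetero atom, a hydrogen-bond donor and a defined stereocentre at this place. Nothing measured here explains the size of this step.

The compounds shown do not separate the contribution of the ring nitrogen from that of the hydroxyl group. An unsubstituted piperidin-1-yl or a morpholin-4-yl on the sulfonyl sulfur would bear on that question.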